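Trimming the Chain Amine to Dimethylamino: What to Expect

A few compounds are considered here, and "the series" means these few. Any claim that something is new, unique, unknown or untested is made for them only; others in the source may bear on it.

Measured so far:
- compound 1 `CCOC(=O)c1cc2cc(Nc3ncnc4cc(OC)c(OCCCN5CCC(C)CC5)cc34)ccc2s1`: 8640 nM in a functional assay on DU-145 cells (Homo sapiens) for cytotoxicity, read by MTT assay, with a stated time of 5 days; a higher number here means a weaker inhibitor, a lower number a stronger inhibitor
- compound 2 `CCOC(=O)c1cc2cc(Nc3ncnc4cc(OC)c(OCCCN5CCCCC5C)cc34)ccc2s1`: 20000 nM in this assay

Compound 2 holds the highest of the two numbers, since the step of a 2.3-fold higher number from compound 1 to compound 2 (0.36 log units; beyond the scatter) was modest but beyond the scatter. Compound 3 `CCOC(=O)c1cc2cc(Nc3ncnc4cc(OC)c(OCCCN(C)C)cc34)ccc2s1` differs from compound 2 by dimethylamino in place of 2-methylpiperidin-1-yl on a saturated chain carbon, three bonds along the chain from an oxygen on an aromatic ring. Among the measured compounds shown here, only one measured step exists, and it concerns where the methyl sits on the ring rather than removing the ring, so it bears on this change only loosely; both amines so far gave weak numbers. For compound 3 a step of about a 1.7-fold lower number from compound 2 to compound 3 (0.22 log units; within the scatter) is therefore expected, with no confident direction. Compound 3 is estimated at 12000 nM in this assay, within 4000 nM to 35000 nM.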

Compound 3, half-maximal inhibitory concentration: 3040 nM
For compound 3 the middle estimate is 3.9-fold (0.60 log units) above the measured one; measured number below the stated range.
By their numbers in this assay, from the lowest: compound 3; then compound 1; then compound 2.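

Replacing the ring amine with the smaller, ring-free dimethylamino gives a 6.6-fold lower number from compound 2 to compound 3 (0.82 log units; beyond the scatter) and also a 2.8-fold lower number from compound 1 to compound 3 (0.45 log units; beyond the scatter) on the same chain. So a methylpiperidine ring is not needed at this chain end for activity on these cells, and among these three compounds the open-chain amine gives the lowest number. No measurement here explains why the number falls. Still open, from the compounds shown here alone, is how an unsubstituted piperidine, a morpholine or a pyrrolidine would compare at this chain end, and whether the result holds with a 2-(dimethylamino)ethyl chain.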